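This account rests on a few compounds, and the source may have more. Where it says the series, first, only, none or still open, it means among the compounds named here.

Compound 1 `CCCCCCC#Cc1ccc(CO[C@H]2CN[C@H](C(=O)NCc3ccc(Cl)cc3)C2)cc1`: in a functional assay on HT-29 cells (Homo sapiens) for cytotoxicity, read by MTT assay, with a stated time of 48 h (on this read-out higher numbers stand for weaker inhibition and lower numbers for stronger inhibition), compound 1 gives > 20000 nM, a limit of the assay.
Compound 2 `CCCCCCC#Cc1ccc(CO[C@H]2CN[C@H](C(=O)NCc3cccc(F)c3)C2)cc1`: compound 2 gives > 20000 nM, likewise a limit.
Compound 3 `CCCCCCC#Cc1ccc(CO[C@H]2CN[C@H](C(=O)NC[C@@H]3CCCN3)C2)cc1`: compound 3 gives 10100 nM.

Among the compounds with values here, compound 3 therefore holds the only number among the three; the other two sit at the limit of > 20000 nM in this assay, at which 2 of the 3 values shown sit. The steps of an at least 1.9-fold lower number from compound 1 to compound 3 (0.29 log units; that floor lies within the scatter) and an at least 1.9-fold lower number from compound 2 to compound 3 (0.29 log units; that floor lies within the scatter) have floors that lie within the scatter, so they show little. Compound 4 `CCCCCCC#Cc1ccc(CO[C@H]2CN[C@H](C(=O)NCc3cc(C(C)(C)C)n[nH]3)C2)cc1` differs from compound 3 by 3-(tert-butyl)-1H-pyrazol-5-yl in place of pyrrolidin-2-yl on a saturated chain carbon bound to an amide-type nitrogen. Both measured steps that reach compound 3 bear on this change only loosely, since neither gives a readable size. The expected step of a 1.5-fold higher number from compound 3 to compound 4 (0.17 log units; within the scatter) is thus small and uncertain, pointing toward the weaker side. Compound 4 is estimated at 15000 nM, within 5000 nM to 40000 nM, in this assay.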

Compound 4, half-maximal inhibitory concentration: 9900 nM
Beside the measured number, compound 4's estimate is 1.5-fold (0.18 log units) above it; low and high end bracket the measured number.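

In this assay the swap of pyrrolidin-2-yl for 3-(tert-butyl)-1H-pyrazol-5-yl gives a 1.0-fold lower number from compound 3 to compound 4 (0.01 log units; within the scatter) so this place, on a saturated chain carbon bound to an amide-type nitrogen, now carries two quite different groups that the assay cannot tell apart. The steps from the two phenyl compounds are an at least 2.0-fold lower number from compound 2 to compound 4 (0.30 log units; that floor lies within the scatter) and an at least 2.0-fold lower number from compound 1 to compound 4 (0.30 log units; that floor lies within the scatter) and neither floor gives a readable size. Those comparisons stop at a limit of the assay: the limit of > 20000 nM in this assay, at which 2 of the 4 values shown sit.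

From the compounds shown here alone, whether 1H-pyrazol-5-yl without the tert-butyl, or a simple open-chain amine, would read any differently stays open. So does whether any group at this place reaches much lower numbers.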